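This account rests on a few compounds, and the source may have more. Where it says the series, first, only, none or still open, it means among the compounds named here.

Compound 2 `O=C(NS(=O)(=O)c1ccc(NC(=O)c2ccc(Cl)cc2Cl)cc1)c1ccccc1` carries a benzamido on its sulfonyl sulfur, and in a functional assay on HEK293 cells for agonist activity at probable G-protein coupled receptor 27 (Homo sapiens), read by a luciferase reporter and beta-arrestin recruitment, with a stated time of 10 min (on this read-out higher numbers stand for larger maximal responses and lower numbers for smaller maximal responses), compound 2 gives "not determined" (no result reported), so no single number describes where it stands. The same is true of compound 3 `O=C(Nc1cccc(S(=O)(=O)Nc2ccccc2)c1)c1ccc(Cl)cc1Cl`, for which this assay likewise gives "not determined" (no result reported). The only measured maximal response in the set comes from compound 1 `O=C(Nc1ccc(S(=O)(=O)Nc2ccccc2)cc1)c1cc(F)c(Cl)cc1F`, which in this assay reaches 37%.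

Compound 4 `CN(c1ccccc1)S(=O)(=O)c1ccc(NC(=O)c2ccc(Cl)cc2Cl)cc1` is derived from compound 2 by a single change (methyl(phenyl)amino in place of benzamido on a sulfonyl sulfur). Within the data shown here, since no step between measured compounds that differ in one place is available, and compound 2 itself has no number, the size and direction of the change in this assay cannot be read from the data; the step could be small, within the scatter, or larger in either direction. Among the measured compounds shown here, the only guide is compound 1, whose 37% shows that a sulfonamide of this type bearing a phenyl on the nitrogen can give a partial maximal response in this assay.

On that basis compound 4 is expected to give about 30% in this assay, with the estimate spanning from 5% to 65%. The width of that span reflects the fact that compound 2 has no single number in this assay, its entry being "not determined" (no result reported).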

Compound 4, largest response reached (Emax), in percent of the reference or control that the assay uses: 50%
Estimate against measurement, compound 4: 20 percentage points below, and the stated range covers the measured number.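

In this assay compound 4 gives 50% but compound 2 has no single number, so no step can be read between compound 2 and compound 4. The compounds shown leave open how replacing benzamido with methyl(phenyl)amino alters the maximal response. Nothing shown here offers an explanation for the result of compound 4.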